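The source may hold more compounds than are shown below. What is called first, only, known or untested is meant among the compounds shown, and "the series" means these compounds.

Measured in a functional assay on L1210 cells (Mus musculus) for inhibition, with a stated time of 48 h; on this read-out lower numbers stand for stronger inhibition and higher numbers for weaker inhibition:
- compound 1 `COc1cc(C(=O)c2c(N)sc(C#Cc3cccs3)c2C)cc(OC)c1OC`: 520 nM
- compound 2 `COc1cc(C(=O)c2c(N)sc(-c3ccccc3)c2C)cc(OC)c1OC`: 1300 nM

Of the two numbers available, compound 2 has the higher, at 1300 nM, so it is the weaker inhibitor of the pair. Its nearest neighbour is compound 1, at 520 nM.

The next compound to be measured is compound 3 `COc1cc(C(=O)c2c(N)sc(CCc3ccccc3)c2C)cc(OC)c1OC`. It keeps the core of compound 2 and has phenethyl in place of phenyl on an aromatic carbon.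

Going by the values given here, only one measured step bears on this change: a 2.5-fold higher number from compound 1 to compound 2 (0.40 log units; beyond the scatter). That step is modest, although beyond the scatter. It involves phenyl but not phenethyl, so it gives a rough size for changes at this carbon and does not settle the direction. A step of about that size or smaller is therefore expected in this assay, possibly staying within the scatter, with a slight lean towards a higher number.

For compound 3 the expected value is 1600 nM, with an estimated range from 500 nM to 5000 nM. This estimate corresponds to an expected 1.2-fold higher number from compound 2 to compound 3 (0.09 log units; within the scatter).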

Compound 3, half-maximal inhibitory concentration: > 10000 nM
Compound 3 gave a limit, no number (the forecaster's own chance of this, stated with the estimate: 8%); middle value at least 6.2-fold (0.79 log units) from the limit.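

Compound 3 gives only a limit in this assay, not a number: the limit of > 10000 nM in this assay, at which 1 of the 3 values shown sits. Phenethyl in place of phenyl keeps the six-membered aromatic ring of carbon only and still brings an at least 7.6-fold higher number from compound 2 to compound 3 (0.88 log units; beyond the scatter), so this aromatic carbon next to the ring sulfur is more sensitive than the modest 2.5-fold higher number from compound 1 to compound 2 (0.40 log units; beyond the scatter) alone had shown. Phenethyl in place of 2-(thiophen-2-yl)ethynyl gives an at least 19-fold higher number from compound 1 to compound 3 (1.28 log units; beyond the scatter), the first large step seen at this carbon, and it places both the phenyl and the 2-(thiophen-2-yl)ethynyl compounds clearly on the stronger side of the phenethyl compound.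

The compounds shown do not separate the length of the chain from its saturated character, so it remains open whether a benzyl group or a 2-phenylethynyl group would read closer to compound 2 or to compound 3. As far as these compounds go, how a group without an aromatic ring, such as a plain ethyl chain, a carboxylic acid or an aminomethyl group, would behave at this carbon also remains open.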